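Swapping Phenyl for Dihydroxyphenyl in Compound 4

The source may report more compounds than this note shows. Statements on the series, on what has been measured and on what is new or still open speak of the compounds shown alone.

Three measured compounds share one core and differ only in the group on a carbon with a double bond to nitrogen. In a functional assay on MKN-45 cells (Homo sapiens) for cytotoxicity, read by MTT assay, with a stated time of 72 h (on this read-out higher numbers stand for weaker inhibition and lower numbers for stronger inhibition), compound 1 `CN(C)CCn1cnnc1-c1cc(Oc2ccc(NC(=O)N/N=C/c3c[nH]c4ccccc34)cc2F)ccn1` gives 790 nM. Compound 2 `COc1ccc(/C=N/NC(=O)Nc2ccc(Oc3ccnc(-c4nncn4CCN(C)C)c3)c(F)c2)c(OC)c1` gives 1680 nM in this assay, and compound 3 `CN(C)CCn1cnnc1-c1cc(Oc2ccc(NC(=O)N/N=C/c3ccccc3)cc2F)ccn1` gives 2730 nM. Compound 3 thus holds the highest of the three numbers: the step of a 3.5-fold higher number from compound 1 to compound 3 (0.54 log units; beyond the scatter) lies beyond the scatter, whereas a 1.6-fold higher number from compound 2 to compound 3 (0.21 log units; within the scatter) falls within it, so compound 3 and compound 2 cannot be ordered. Between the other pair, a 2.1-fold higher number from compound 1 to compound 2 (0.33 log units; beyond the scatter).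

Compound 4 `CN(C)CCn1cnnc1-c1cc(Oc2ccc(NC(=O)N/N=C/c3ccc(O)c(O)c3)cc2F)ccn1` is not yet measured; it differs from compound 3 by 3,4-dihydroxyphenyl in place of phenyl on a carbon with a double bond to nitrogen. For the measured compounds named here, the nearest precedent is the pair of compound 2 and compound 3, where methoxy groups came and went without a step beyond the scatter. Going by the values given here, the 1H-indol-3-yl group of compound 1 moved the number further, but no measured step involves hydroxyl groups. Compound 4 is therefore expected to show a step of about a 1.4-fold lower number from compound 3 to compound 4 (0.14 log units; within the scatter), within the scatter. Compound 4 is estimated at 2000 nM, with a range from 700 nM to 5500 nM.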

Compound 4, half-maximal inhibitory concentration: 3240 nM
For compound 4 the middle estimate is 1.6-fold (0.21 log units) below the measured one, within the range that was stated.
By their numbers in this assay, from the lowest: compound 1; then compounds 2, 3 and 4 (each within the scatter of the next).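

In this assay, for the compounds shown here, 3,4-dihydroxyphenyl in place of phenyl on a carbon with a double bond to nitrogen gives no step beyond the scatter (a 1.2-fold higher number from compound 3 to compound 4 (0.07 log units; within the scatter)), and the same holds against the 2,4-dimethoxyphenyl group (a 1.9-fold higher number from compound 2 to compound 4 (0.29 log units; within the scatter)), so compounds 2, 3 and 4 cannot be ordered even though the new group brings hydroxyl groups that no earlier compound carried. Compound 1 alone stands apart from all three, and the new compound widens the largest gap shown (a 4.1-fold higher number from compound 1 to compound 4 (0.61 log units; beyond the scatter)). No measurement offered here accounts for these numbers.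

Going by these compounds, it remains open whether a single hydroxyl group, an amine or a carboxylic acid on the phenyl group would move the number beyond the scatter. On these data alone, it is also open whether any group other than 1H-indol-3-yl on this carbon can match compound 1.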